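This account rests on a few compounds, and the source may have more. Where it says the series, first, only, none or still open, it means among the compounds named here.

Compound 1 `O=C(N/N=C/c1ccccc1)c1cnccn1`: 100%
Compound 2 `O=C(N/N=C/c1cccc(Cl)c1)c1cnccn1`: 100%
Compound 3 `O=C(N/N=C/c1cccc(F)c1)c1cnccn1`: 49%

These numbers come from an ADME assay on J774 cells (Mus musculus) for cytotoxicity, read by MTT assay, with a stated time of 48 h, tested at 50 ug/mL; a higher number here means a weaker effect of the compound at the concentration tested, a lower number a stronger effect. Compound 3 stands lowest of the three: a number 51 percentage points lower from compound 1 to compound 3 (beyond the scatter) and a number 51 percentage points lower from compound 2 to compound 3 (beyond the scatter), both beyond the scatter.

Compound 4 `O=C(N/N=C/c1cccc(Br)c1)c1cnccn1` is not yet measured. It differs from compound 3 by bromo in place of fluoro on an aromatic carbon. Within the data shown here, no measured step swaps fluoro for bromo. Among the measured compounds shown here, two measured steps bear on it: no change at the digits printed from compound 1 to compound 2 (within the scatter), whereas a number 51 percentage points lower from compound 1 to compound 3 (beyond the scatter). The low reading thus appears only with fluoro, and the chloro compound 2 reads like the unsubstituted compound 1. A large upward step is expected for compound 4, a number 36 percentage points higher from compound 3 to compound 4 (beyond the scatter) in this assay. The estimate for compound 4 is 85%, with a range from 45% to 100%.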

Compound 4, a percentage reported as activity, at one concentration (the size of the read-out at that concentration, not a potency): 100%
The estimate for compound 4 lay 15 percentage points below the measured number; the measured number falls inside the stated range.
By their numbers in this assay, from the lowest: compound 3; then compounds 1, 2 and 4 (each within the scatter of the next).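

In this assay, the low reading at this place on the ring now belongs to fluoro alone among the three halogens shown: a number 51 percentage points higher from compound 3 to compound 4 (beyond the scatter). Bromo matches chloro, with no change at the digits printed from compound 2 to compound 4 (within the scatter), and also matches hydrogen, with no change at the digits printed from compound 1 to compound 4 (within the scatter), so the numbers do not shift step by step from fluoro through chloro to bromo, and compound 3 is the only one that stands apart. Nothing measured here explains why fluoro alone differs.

The compounds shown leave open how a methoxy group or an amine at this same place would read, and so whether compound 3 remains the lone exception.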